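This account rests on a few compounds, and the source may have more. Where it says the series, first, only, none or still open, it means among the compounds named here.

Compound 1 `CC(C)C(=O)Oc1c(C(C)C)cc2c3c1OC(=O)[C@@]31CCCC(C)(C)[C@@H]1CC2` carries an isopropyl group on a carbonyl carbon. In an ADME assay on MRC5 cells (Homo sapiens) for cytotoxicity, read by neutral red uptake, with a stated time of 24 h (on this read-out higher numbers stand for weaker inhibition and lower numbers for stronger inhibition), compound 1 gives 119000 nM, the highest of the three numbers gathered so far. Compound 2 `CCCC(=O)Oc1c(C(C)C)cc2c3c1OC(=O)[C@@]31CCCC(C)(C)[C@@H]1CC2` gives 44400 nM in this assay, and compound 3 `CC(C)c1cc2c3c(c1OC(=O)Cc1c[nH]c4ccccc14)OC(=O)[C@@]31CCCC(C)(C)[C@@H]1CC2` gives 109000 nM. Two steps lead away from compound 1: a 2.7-fold lower number from compound 1 to compound 2 (0.43 log units; beyond the scatter), and a 1.1-fold lower number from compound 1 to compound 3 (0.04 log units; within the scatter). Compound 4 `CC(C)c1cc2c3c(c1OC(=O)CCCc1c[nH]c4ccccc14)OC(=O)[C@@]31CCCC(C)(C)[C@@H]1CC2` has not yet been measured. It differs from compound 1 in this way: 3-(1H-indol-3-yl)propyl in place of isopropyl on a carbonyl carbon. Both known steps bear on this change. Compound 4 joins a longer chain, of the kind present in compound 2, to the indole present in compound 3. Lengthening the chain moved the number modestly downward, a 2.7-fold lower number from compound 1 to compound 2 (0.43 log units; beyond the scatter), while attaching the indole left it within the scatter, a 1.1-fold lower number from compound 1 to compound 3 (0.04 log units; within the scatter). A modest lowering, of the size seen for the chain alone, is therefore the expectation. Compound 4 is estimated at 65000 nM, in a range from 30000 nM to 140000 nM, which would mean an expected 1.8-fold lower number from compound 1 to compound 4 (0.26 log units; within the scatter).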

Compound 4, half-maximal inhibitory concentration: 54500 nM
The estimate for compound 4 lay 1.2-fold (0.08 log units) above the measured number; the measured number falls inside the stated range.
By their numbers in this assay, from the lowest: compounds 2, 4, 3 and 1 (each within the scatter of the next, the first and the last beyond it).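

In this assay the 3-(1H-indol-3-yl)propyl group gives a 2.2-fold lower number from compound 1 to compound 4 (0.34 log units; beyond the scatter) and so, unlike the shorter indole-bearing group of compound 3, moves the number beyond the scatter. Adding the indole to the end of the chain makes no clear difference, with a 1.2-fold higher number from compound 2 to compound 4 (0.09 log units; within the scatter) staying within the scatter, so this position on the carbonyl carbon takes the two added rings without a readable shift. Lengthening the link to the indole gives a 2.0-fold lower number from compound 3 to compound 4 (0.30 log units; within the scatter) and also stays within the scatter, so the effect of link length alone remains unresolved between these two compounds.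

Going by these compounds, whether an amine or a carboxylic acid at the end of the chain would match the indole remains open, as does the outcome for a chain longer than that of compound 4. Nothing shown here explains these numbers.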